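This account rests on a few compounds, and the source may have more. Where it says the series, first, only, none or still open, it means among the compounds named here.

In a functional assay on Jurkat cells (Homo sapiens) for cytotoxicity, read by MTT assay, with a stated time of 24 h (on this read-out lower numbers stand for an effect already at smaller amounts and higher numbers for an effect only at larger amounts of compound), compound 1 (`COc1ccc([Se]c2cc(-c3ccc(O)cc3)nc3ccc(OC)cc23)cc1`) gives 41500 nM. Going by the values given here, the only other measured compound, compound 2 (`CCOC(=O)c1cc([Se]c2ccccc2)c2cc(Cl)ccc2n1`), gives 53000 nM. These two numbers lie within the usual scatter of each other, so they cannot be told apart. Compound 3 (`CCOC(=O)c1cc([Se]c2ccc(OC)cc2)c2cc(OC)ccc2n1`) has not yet been measured. Its structure differs from that of compound 1 as follows: ethoxycarbonyl in place of 4-hydroxyphenyl on an aromatic carbon. In plain terms, ethoxycarbonyl stands in place of 4-hydroxyphenyl on an aromatic carbon, next to the ring nitrogen. Among the compounds with values here, no measured pair shows this exchange on its own, so the evidence is thin. Still, compound 2 also carries ethoxycarbonyl and gives 53000 nM, so no change beyond the scatter is expected in this assay. The expected step is small: a 1.1-fold higher number from compound 1 to compound 3 (0.04 log units; within the scatter). For compound 3 the estimated value is 45000 nM, with an expected range from 20000 nM to 100000 nM.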

Compound 3, half-maximal effective concentration: 82500 nM
The estimate for compound 3 lay 1.8-fold (0.26 log units) below the measured number; low and high end bracket the measured number.
By their numbers in this assay, from the lowest: compounds 1, 2 and 3 (each within the scatter of the next).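

Going by these compounds alone, compound 1 and compound 3 are the first pair to isolate this change on the aromatic carbon next to the ring nitrogen: 4-hydroxyphenyl, a ring with a hydrogen-bond donor, gives way to ethoxycarbonyl, which has no ring and no donor. In this assay this large exchange gives only a small step (a 2.0-fold higher number from compound 1 to compound 3 (0.30 log units; within the scatter)), so the two compounds cannot be told apart, and the read-out shows no clear sensitivity to this swap. Nothing at hand gives a reason for the size of this step.

With just these two groups compared here, the pair cannot separate any role of the ring from that of the hydroxyl. As far as these compounds go, whether an amine, a carboxylic acid or a longer chain on this carbon would move the number beyond the scatter stays open.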